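Urea aryl swap on a pyrazole-pyridine series

The source may hold more compounds than are shown below. What is called first, only, known or untested is meant among the compounds shown, and "the series" means these compounds.

Measured compounds:
- Compound 1, `O=C(Nc1cccc(-n2cc(-c3ccncc3)c(-c3ccc(Cl)c(O)c3)n2)c1)Nc1cccc(C(F)(F)F)c1`: 7260 nM
- Compound 2, `COc1cc(-c2nn(-c3cccc(NC(=O)Nc4ccc(Cl)c(Cl)c4)c3)cc2-c2ccncc2)ccc1Cl`: 1560 nM

In a functional assay on HCC 2998 cells (Homo sapiens) for inhibition, read by sulforhodamine B assay, with a stated time of 48 h (on this read-out lower numbers stand for stronger inhibition of growth and higher numbers for weaker inhibition of growth), compound 2 gives 1560 nM, the lowest of the two numbers recorded; compound 1, with 7260 nM, sits well beyond the usual scatter above it. Compounds 1 and 2 differ in two places at once, so their two values alone say nothing about either change by itself.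

Compound 3, `COc1cc(-c2nn(-c3cccc(NC(=O)Nc4cccc(C(F)(F)F)c4)c3)cc2-c2ccncc2)ccc1Cl`, has not been measured. It differs from compound 2 in one place only: 3-(trifluoromethyl)phenyl in place of 3,4-dichlorophenyl on an amide-type nitrogen. Compound 3 therefore carries the same urea aryl group as compound 1 while keeping the rest of compound 2 unchanged.

Within the data shown here, no single-change step covering this swap is available among the measured compounds, so the size of the step is uncertain. Given that compound 1 gives 7260 nM and compound 2 gives 1560 nM, the account expects compound 3 to lose some inhibition relative to compound 2, with a step of a 2.2-fold higher number from compound 2 to compound 3 (0.35 log units; beyond the scatter) that may or may not exceed the scatter. The estimate for compound 3 in this assay is 3500 nM, with a range from 1200 nM to 10000 nM.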

Compound 3, concentration for 50% growth inhibition: 1190 nM
Beside the measured number, compound 3's estimate is 2.9-fold (0.47 log units) above it, and the stated range ends above it.
By their numbers in this assay, from the lowest: compounds 3 and 2 (each within the scatter of the next); then compound 1.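

In this assay, 3-(trifluoromethyl)phenyl in place of 3,4-dichlorophenyl on an amide-type nitrogen gives a 1.3-fold lower number from compound 2 to compound 3 (0.12 log units; within the scatter), so at this position the two aryl groups cannot be told apart on this read-out. Compound 3 also isolates the other change that was tangled in the first pair: methyl in place of hydrogen on an oxygen on an aromatic ring gives a 6.1-fold lower number from compound 1 to compound 3 (0.79 log units; beyond the scatter). Of the two single changes now visible, only this one on the oxygen carries a step beyond the scatter, a reading that rests on these three compounds alone. The data shown offer no evidence on why either step has the size it does.

On these data alone, it remains open whether the urea aryl swap would read the same in a compound carrying hydrogen on that oxygen, and whether an aryl group bearing a nitrile, an amine or a carboxylic acid would also leave the number within the scatter. As far as these compounds go, it is equally open whether ethyl or a longer chain on the oxygen would extend the step seen with methyl, or reverse it.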